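The compounds below may be only part of what the source reports. "The series", "measured", "known", "first", "only" and "open" are said of these compounds alone.

Two members of the series have numbers in a functional assay on CHO cells with adenosine receptor A1 (Homo sapiens) as the target, read by cAMP accumulation and immunoassay, with a stated time of 6 min, tested at 10 uM (a higher number here means a weaker effect of the compound at the concentration tested, a lower number a stronger effect), so far. Compound 1, `Nc1scc(CN2CCN(c3ccc(OC(F)(F)F)cc3)CC2)c1C(=O)c1ccc(Cl)cc1`, gives -74%. Going by the values given here, compound 2, `Nc1scc(CN2CCN(c3cccnc3)CC2)c1C(=O)c1ccc(Cl)cc1`, gives -23%, the highest of the two numbers; its nearest neighbour is compound 1, and the step between them, a number 51 percentage points higher from compound 1 to compound 2 (beyond the scatter), is the only measured step in the set.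

The next compound, compound 3, is `Nc1scc(CN2CCN(c3ccc(F)cc3F)CC2)c1C(=O)c1ccc(Cl)cc1`. It differs from compound 2 in one place: 2,4-difluorophenyl in place of pyridin-3-yl on an amine nitrogen in a ring. Among the compounds with values here, the one measured step bears on this change in the reverse sense, since it went from a phenyl bearing a substituent to pyridin-3-yl and raised the number by a large amount. Returning to a phenyl ring, here with two fluorine atoms, is therefore expected to lower the number again, by a step of about a number 32 percentage points lower from compound 2 to compound 3 (beyond the scatter). Compound 3 is estimated at -55%, with a range from -82% to -22%.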

Compound 3, a percentage reported as activity, at one concentration (the size of the read-out at that concentration, not a potency): -82%
The estimate for compound 3 lay 27 percentage points above the measured number, within the range that was stated.
By their numbers in this assay, from the lowest: compounds 3 and 1 (each within the scatter of the next); then compound 2.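

In this assay, a second substituted phenyl ring now stands against pyridin-3-yl on the amine nitrogen in the ring, and a number 59 percentage points lower from compound 2 to compound 3 (beyond the scatter) runs opposite to a number 51 percentage points higher from compound 1 to compound 2 (beyond the scatter). Exchanging one substituted phenyl ring for the other, 2,4-difluorophenyl in place of 4-(trifluoromethoxy)phenyl, gives a number 8 percentage points lower from compound 1 to compound 3 (within the scatter), so compound 1 and compound 3 cannot be told apart here, and among these three compounds only the pyridin-3-yl member, compound 2, stands apart. No evidence to hand accounts for the size of these steps.

From the compounds shown here alone, whether the ring substituents matter at all remains open, as unsubstituted phenyl would test that directly. Equally open, going by these compounds, is how a saturated group such as cyclohexyl would behave at this place.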